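Swapping a Chloro for a Methyl on Two Cores

The compounds below may be only part of what the source reports. "The series", "measured", "known", "first", "only" and "open" are said of these compounds alone.

Measured compounds:
- compound 1, `Clc1ccc(-c2ccnc3c2c(-c2ccccc2)nn3-c2ccccc2)cc1`: 61100 nM
- compound 2, `Cc1ccc(-c2ccnc3c2c(-c2ccccc2)nn3-c2ccccc2)cc1`: 10700 nM
- compound 3, `O=C(C=CNc1cc(-c2ccccc2)nn1-c1ccccc1)c1ccc(Cl)cc1`: 41200 nM

Of the compounds shown here, three have been tested in a functional assay on HepG2 cells (Homo sapiens) for inhibition, read by MTT assay, with a stated time of 48 h; a higher number here means a weaker inhibitor, a lower number a stronger inhibitor. Compound 1 and compound 2 share one core, and compound 3 has a different core; the difference between the two cores is not broken down here. In this assay compound 3 gives 41200 nM, a number that sits within the scatter of compound 1 and beyond the scatter of compound 2.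

Within the first core, one change has been made: methyl in place of chloro on an aromatic carbon. In this assay this gave a 5.7-fold lower number from compound 1 to compound 2 (0.76 log units; beyond the scatter).

The unmeasured compound 4, `Cc1ccc(C(=O)C=CNc2cc(-c3ccccc3)nn2-c2ccccc2)cc1`, carries the same change on the second core: methyl in place of chloro on an aromatic carbon. The place of the change is described in the same words for both pairs, so it is the same change. The cores differ, however, and that difference is not broken down, so the surroundings of the change are not the same. The expectation for compound 4 rests on one step only, from compound 1 to compound 2, and a single step on another core is a thin base. A step of similar direction, somewhat smaller in size, is expected from compound 3 to compound 4: a 3.4-fold lower number from compound 3 to compound 4 (0.54 log units; beyond the scatter). For compound 4 the estimate in this assay is therefore 12000 nM, with a range from 4000 nM to 40000 nM.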

Compound 4, half-maximal inhibitory concentration: 7320 nM
Compound 4: middle estimate off by 1.6-fold (0.21 log units), on the high side; low and high end bracket the measured number.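

In this assay, putting methyl in place of chloro on the second core gave a 5.6-fold lower number from compound 3 to compound 4 (0.75 log units; beyond the scatter), and this step matches the earlier one on the first core, with no difference that stands out from the scatter: the same change on two cores in this assay, a 5.7-fold lower number (0.76 log units; beyond the scatter) from compound 1 to compound 2 and a 5.6-fold lower number (0.75 log units; beyond the scatter) from compound 3 to compound 4, 1.0-fold (0.01 log units) apart, within the scatter of two such steps

So, in this small series, the step measured on one core carried over to the other in both direction and size, and the difference between the cores did not visibly alter the effect of swapping 4-chlorophenyl for 4-methylphenyl. This does not show why the swap lowers the number, nor does it make a general rule, since the result rests on just two pairs of compounds, a single change and a single cell assay, and a third core could behave differently.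

The compounds shown leave open whether other groups at this place on the ring, such as a fluoro, a methoxy, an amine, a carboxylic acid or a longer chain like ethyl, would also give steps that match across the two cores. They also leave open which part of the difference between the two cores matters for the numbers, since that difference is not broken down into single changes.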